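Cyclopentyl for trifluoromethyl in a fluorinated sulfonamide amide series

The compounds below may be only part of what the source reports. "The series", "measured", "known", "first", "only" and "open" are said of these compounds alone.

Among the measured compounds shown here, compound 3 `CC(C(=O)NCc1ccc(C(F)(F)F)cc1)c1ccc(NS(C)(=O)=O)c(F)c1` sits in the middle of the three numbers so far. In a functional assay on CHO cells for antagonist activity at transient receptor potential cation channel subfamily V member 1 (Rattus norvegicus) (on this read-out lower numbers stand for stronger inhibition and higher numbers for weaker inhibition), compound 3 gives 274 nM. Compound 1 `COc1cc(C2(C(=O)NCc3ccc(C(C)(C)C)cc3)CC2)ccc1NS(C)(=O)=O` gives 2250 nM, the highest number; the gap from compound 3 to compound 1 is beyond the scatter. Compound 2 `CC(NC(=O)/C=C/c1ccc(C(C)(C)C)cc1)c1ccc(NS(C)(=O)=O)c(F)c1` gives 23.9 nM, the lowest number; its gap to compound 3 is also beyond the scatter. For the measured compounds named here, no pair of these three compounds differs in a single place, so no measured step carries directly over to the next compound.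

Compound 4 `CC(C(=O)NCc1ccc(C2CCCC2)cc1)c1ccc(NS(C)(=O)=O)c(F)c1` differs from compound 3 in one place: cyclopentyl in place of trifluoromethyl on an aromatic carbon. Nothing measured in this assay isolates this exchange. The tert-butyl-bearing compound 2 with its 23.9 nM suggests that a saturated carbon group at this place is compatible with a low number, but compound 1, also tert-butyl-bearing, gives 2250 nM, so the substituent alone does not settle the value. A modest step toward a lower number is expected, a 2.3-fold lower number from compound 3 to compound 4 (0.36 log units; beyond the scatter), with wide uncertainty. For compound 4 the estimate is 120 nM, expected to lie between 30 nM and 500 nM.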

Compound 4, inhibition constant: 20.8 nM
Estimate against measurement, compound 4: 5.8-fold (0.76 log units) above; measured number below the stated range.
By their numbers in this assay, from the lowest: compounds 4 and 2 (each within the scatter of the next); then compound 3; then compound 1.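

Among the compounds shown here, exchanging trifluoromethyl for cyclopentyl on the aromatic carbon para to a large group gives a 13-fold lower number from compound 3 to compound 4 (1.12 log units; beyond the scatter) in this assay and is the only single-place step so far. This position is therefore sensitive to its substituent: with the rest of the molecule unchanged, the number moves beyond the scatter, and a five-membered carbon ring is compatible with a low number here. Nothing available accounts for the size of this step.

A single exchange does not separate the contribution of the ring from that of saturated carbon in general. Open also are how a cyclohexyl ring, an open butyl chain or a morpholine would read at this carbon, and whether cyclopentyl for trifluoromethyl carries over to the cores of compound 1 and compound 2.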